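Replacing the ring hydroxy of compound 2 with hydrogen

This account rests on a few compounds, and the source may have more. Where it says the series, first, only, none or still open, it means among the compounds named here.

In a functional assay on KB cells (Homo sapiens) for cytotoxicity, read by MTT assay, with a stated time of 48 h (on this read-out lower numbers stand for stronger inhibition and higher numbers for weaker inhibition), compound 1 `C=C[C@@]1(C)COC(=O)[C@]12OC([C@H](C)CC)=CC2=O` gives > 100 ug/mL as a limit of the assay, not a number. Compound 2 `C=C[C@@]1(C)COC(=O)C1(O)C(=O)/C=C(\O)c1ccccc1` likewise gives > 100 ug/mL as a limit, and it stands at the limit of > 100 ug/mL in this assay, at which 2 of the 2 values shown sit, in this small series. Compound 3 `C=C[C@@]1(C)COC(=O)C1C(=O)/C=C(\O)c1ccccc1` departs from compound 2 by hydrogen in place of hydroxy on a saturated ring carbon and amounts to hydrogen in place of hydroxy on a saturated ring carbon. Within the data shown here, no measured step bears on this change, so in this assay no shift beyond the scatter is expected, and the expected step of a number no higher from compound 2 to compound 3 (the limit leaves the size open) is small. The expectation rests only on compound 2 at > 100 ug/mL as a limit. For compound 3 the estimated value is 100 ug/mL with an expected range of 35 ug/mL to 250 ug/mL here.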

Compound 3, half-maximal inhibitory concentration: 61 ug/mL
The estimate for compound 3 lay 1.6-fold (0.21 log units) above the measured number, within the range that was stated.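

Hydrogen in place of hydroxy on a saturated ring carbon gives the first readable number of this small series in this assay, where compound 3 gives 61 ug/mL. From the compounds shown here alone, the step is an at least 1.6-fold lower number from compound 2 to compound 3 (0.21 log units; that floor lies within the scatter), so its true size stays open. The rest of the series gives no number to set beside it: the limit of > 100 ug/mL in this assay, at which 2 of the 3 values shown sit.

Whether this change moves the value beyond the scatter remains unsettled. Also open, going by these compounds, is what an amine or a methoxy group would do on this ring carbon, or a longer chain in place of the vinyl group.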